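Nitro in Place of Methoxy, Starting From a Limit

The compounds below may be only part of what the source reports. "The series", "measured", "known", "first", "only" and "open" are said of these compounds alone.

Compound 1 `CC(=O)Oc1ccc(/C=C/c2nc3ccccc3c(=O)[nH]2)c(OC(C)=O)c1` and compound 2 `COc1ccc(/C=C/c2nc3ccccc3c(=O)[nH]2)cc1` share one core, and both were tested in a functional assay on HCT-116 cells (Homo sapiens) for antiproliferative activity, with a stated time of 72 h; a higher number here means a weaker inhibitor, a lower number a stronger inhibitor. Compound 1 gives > 25000 nM, which is a limit and not a number. Compound 2 gives > 25000 nM, which is also only a limit. From the compounds shown here alone, compound 2 therefore stands at the edge of what the measurement reports, and its true potency is unknown. Within the data shown here, the evidence so far amounts to the limit of > 25000 nM in this assay, at which 2 of the 2 values shown sit, so no step between measured compounds is available to guide a forecast.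

Compound 3 `O=c1[nH]c(/C=C/c2ccc([N+](=O)[O-])cc2)nc2ccccc12` keeps the core of compound 2 and changes one group: nitro in place of methoxy on an aromatic carbon. Nitro takes the place of methoxy on an aromatic carbon, para to a large group. With no measured gain to build on, no shift beyond the usual scatter is expected in either direction in this assay, and another limit is the likeliest result. The expected step is a number no higher from compound 2 to compound 3 (the limit leaves the size open). For compound 3 the estimated value is 25000 nM. The expected range runs from 10000 nM to 50000 nM.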

Compound 3, half-maximal inhibitory concentration: > 25000 nM
Compound 3: only a limit was reported (the forecaster's own chance of this, stated with the estimate: 65%); the middle value sits exactly at the limit.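

Among these compounds, no step from compound 2 to compound 3 can be read in this assay, so the effect of nitro in place of methoxy on an aromatic carbon stays unknown. The compounds share one result: the limit of > 25000 nM in this assay, at which 3 of the 3 values shown sit. What they leave open is how potent any of them truly is, and whether any change to the shared core would give a measurable value in this assay.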